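A further chloro on a weakly cytotoxic compound

The compounds below may be only part of what the source reports. "The series", "measured", "known", "first", "only" and "open" are said of these compounds alone.

- Compound 1 `Cc1cc(O)c(C(=O)/C=C/c2ccc(F)cc2)c(=O)o1`: > 100000 nM (a limit, not a number)
- Compound 2 `Cc1cc(O)c(C(=O)/C=C/c2ccc(Cl)cc2)c(=O)o1`: 87400 nM

For the measured compounds named here, in a functional assay on HCT-116 cells (Homo sapiens) for cytotoxicity, read by MTT assay (on this read-out lower numbers stand for stronger inhibition and higher numbers for weaker inhibition), compound 2 gives 87400 nM, the only true number so far. Compound 1 gives > 100000 nM, which is a limit of the assay, as the limit of > 100000 nM in this assay, at which 1 of the 2 values shown sits, records. Going by the values given here, the single measured step, an at least 1.1-fold lower number from compound 1 to compound 2 (0.05 log units; that floor lies within the scatter), puts chloro in place of fluoro, and it cannot be told apart from the scatter.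

Compound 3 `Cc1cc(O)c(C(=O)/C=C/c2ccc(Cl)cc2Cl)c(=O)o1` keeps everything in compound 2 but has chloro in place of hydrogen on an aromatic carbon, ortho to a large group and meta to a chloro group: chloro in place of hydrogen on an aromatic carbon. That measured step involves a different change, so it offers only a weak guide. In this assay, a small shift towards a lower number is expected, and it is not expected to clearly exceed the scatter: a 1.6-fold lower number from compound 2 to compound 3 (0.20 log units; within the scatter). For compound 3 the estimate is 55000 nM, with an expected range of 20000 nM to 100000 nM.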

Compound 3, half-maximal inhibitory concentration: 88700 nM
The estimate for compound 3 lay 1.6-fold (0.21 log units) below the measured number; measured number inside the range.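

In this assay, chloro in place of hydrogen on an aromatic carbon, ortho to a large group and meta to a chloro group, gives a 1.0-fold higher number from compound 2 to compound 3 (0.01 log units; within the scatter). For the compounds shown here, this is the first step here that adds an atom to the ring instead of swapping one halogen for another, and the second chloro leaves compound 3 indistinguishable from compound 2, so neither can be ranked over the other. A move towards weaker numbers would also be hard to see, because the read-out stops at a ceiling: the limit of > 100000 nM in this assay, at which 1 of the 3 values shown sits.

The compounds shown leave open whether a group other than a halogen at this position, such as a methoxy group or an amine, would bring the number clearly down. They also leave open whether changes to the shared core, rather than to this ring, would do so.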